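Shortening the amino acid side chain on a shared core

The source may report more compounds than this note shows. Statements on the series, on what has been measured and on what is new or still open speak of the compounds shown alone.

Measured so far:
- compound 1 `C[C@@H](O)[C@H](NC(=O)CN(c1nc(Cl)nc2[nH]cnc12)C1CC1)C(=O)O`: 37.6%
- compound 2 `CC(C)C[C@H](NC(=O)CN(c1nc(Cl)nc2[nH]cnc12)C1CC1)C(=O)O`: 18.7%

Both compounds were tested in a functional assay on the whole organism (Tail, strain ICR) with Mus musculus as the target, in the tail flick test, with a stated time of 120 min, at a dose of 25 umol/kg by the oral route; a higher number here means a stronger effect of the compound at the dose given, a lower number a weaker effect. Compound 1 gives 37.6% in this assay, and compound 2 gives 18.7%. Among the measured compounds shown here, the only step available is a number 18.9 percentage points lower from compound 1 to compound 2 (beyond the scatter), so compound 2 stands lowest of the two numbers, with compound 1 the nearer and only neighbour.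

Compound 3 `C[C@H](NC(=O)CN(c1nc(Cl)nc2[nH]cnc12)C1CC1)C(=O)O` has not been measured. It differs from compound 2 by hydrogen in place of isopropyl on a saturated chain carbon, two bonds along the chain from an amide-type nitrogen and a carbonyl carbon. Cut one bond further out, the same change reads isobutyl to methyl.

For the measured compounds named here, the one measured step, a number 18.9 percentage points lower from compound 1 to compound 2 (beyond the scatter), touches the same saturated chain carbon, but it swapped a group carrying a hydroxyl for isobutyl; it does not tell what trimming the isobutyl back to methyl does. Going by the values given here, the closest guide is only that a change at this position moved this assay by a modest amount. Compound 3 is therefore expected to sit near compound 2, with a step of a number 5.3 percentage points higher from compound 2 to compound 3 (within the scatter) that may not exceed the scatter. The estimate for compound 3 is 24%, within 8% to 42%.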

Compound 3, a percentage reported as activity, at one dose (the size of the read-out at that dose, not a potency): 28.4%
For compound 3 the middle estimate is 4.4 percentage points below the measured one; low and high end bracket the measured number.
By their numbers in this assay, from the lowest: compounds 2, 3 and 1 (each within the scatter of the next, the first and the last beyond it).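

In this assay the change from isobutyl to methyl on this saturated chain carbon gives a number 9.7 percentage points higher from compound 2 to compound 3 (within the scatter), and methyl in place of 1-hydroxyethyl gives a number 9.2 percentage points lower from compound 1 to compound 3 (within the scatter), so neither change moves the read-out by more than repeated measurements normally vary. The earlier pair showed only that 1-hydroxyethyl and isobutyl give numbers that lie apart; compound 3, with its methyl, cannot be separated from either of them, so the group carrying the hydroxyl is not shown to be needed for the effect at this dose, and the gap between compound 1 and compound 2 remains the only difference here beyond the scatter. No measurement is at hand that says what lies behind these numbers.

Still open, on these data alone, is how this carbon responds to groups of other kinds, such as a chain ending in an amine, a phenyl ring or a chain longer than isobutyl, as three side chains give only a narrow view. Each number also comes from one oral dose at one time point, so it gives the size of the effect there and says nothing about potency or about how the effect changes with dose.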